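Amide aryl variation on a shared flavonol core

The compounds below may be only part of what the source reports. "The series", "measured", "known", "first", "only" and "open" are said of these compounds alone.

Compound 3 `Cc1cccc(C(=O)Nc2cccc(-c3oc4cc(-c5ccc(F)cc5)ccc4c(=O)c3O)c2)c1` stands second highest of the three numbers in a functional assay on HeLa cells (Homo sapiens) for antiproliferative activity, read by CCK-8 assay, with a stated time of 72 h (a higher number here means a weaker inhibitor, a lower number a stronger inhibitor), where compound 3 gives 6650 nM. Its neighbours are compound 1 `O=C(Nc1cccc(-c2oc3cc(-c4ccc(F)cc4)ccc3c(=O)c2O)c1)c1ccccc1F`, which in this assay gives 5630 nM, and compound 2 `O=C(Nc1cccc(-c2oc3cc(-c4ccc(F)cc4)ccc3c(=O)c2O)c1)c1ccc(C(F)(F)F)cc1`, which gives 17400 nM. The measured steps show a 1.2-fold higher number from compound 1 to compound 3 (0.07 log units; within the scatter) and a 2.6-fold lower number from compound 2 to compound 3 (0.42 log units; beyond the scatter), alongside a 3.1-fold higher number from compound 1 to compound 2 (0.49 log units; beyond the scatter). Compound 4 `COc1cc(OC)cc(C(=O)Nc2cccc(-c3oc4cc(-c5ccc(F)cc5)ccc4c(=O)c3O)c2)c1` differs from compound 3 by 3,5-dimethoxyphenyl in place of 3-methylphenyl on a carbonyl carbon. For the measured compounds named here, no measured step involves a dimethoxy-bearing aryl, so the guide is weak; the only step beyond the scatter came from compound 2, and the step from compound 1 to compound 3 stayed within it. Compound 4 is therefore expected to show a 1.3-fold higher number from compound 3 to compound 4 (0.11 log units; within the scatter), an estimate of 8500 nM with a range from 3000 nM to 25000 nM.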

Compound 4, half-maximal inhibitory concentration: 2700 nM
For compound 4 the middle estimate is 3.1-fold (0.50 log units) above the measured one; measured number outside the range, below it.
By their numbers in this assay, from the lowest: compound 4; then compounds 1 and 3 (each within the scatter of the next); then compound 2.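

With 3,5-dimethoxyphenyl on the carbonyl carbon, compound 4 gives the lowest number of the set in this assay, with steps of (a 2.5-fold lower number from compound 3 to compound 4 (0.39 log units; beyond the scatter)), (a 2.1-fold lower number from compound 1 to compound 4 (0.32 log units; beyond the scatter)) and (a 6.4-fold lower number from compound 2 to compound 4 (0.81 log units; beyond the scatter)). The earlier compounds shown here showed this position only holding level or moving to a higher number, so the aryl group here can also move the number lower. No available evidence says why the number falls. On these data alone, whether one methoxy group would be enough remains open, as does how an amine or a carboxylic acid on this aryl ring would read.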